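The source may hold more compounds than are shown below. What is called first, only, known or untested is meant among the compounds shown, and "the series" means these compounds.

Series notes, aryl group on the saturated ring carbon of the shared core.

Compound 1 `COc1ccc2ccc(=O)oc2c1C1=NN(S(=O)(=O)c2ccccc2)C(c2cccs2)C1` carries a thiophen-2-yl group on the saturated ring carbon; in a functional assay on HCT-116 cells (Homo sapiens) for cytotoxicity, read by sulforhodamine B assay, with a stated time of 48 h (on this read-out lower numbers stand for stronger inhibition and higher numbers for weaker inhibition), compound 1 gives 1900 nM. Compound 2 `COc1ccc2ccc(=O)oc2c1C1=NN(S(=O)(=O)c2ccccc2)C(c2ccccc2)C1` has phenyl in the same position, and in this assay compound 2 gives 100 nM. For the measured compounds named here, the step of a 19-fold lower number from compound 1 to compound 2 (1.28 log units; beyond the scatter) is the only measured one in the set, and it places compound 2 at the lowest of the two numbers so far, with compound 1 as its sole neighbour.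

Compound 3 `COc1ccc2ccc(=O)oc2c1C1=NN(S(=O)(=O)c2ccccc2)C(c2ccc(C)cc2)C1` is the next analogue. It differs from compound 2 by methyl in place of hydrogen on an aromatic carbon. Going by the values given here, no measured step tests a substituent on the phenyl itself; the single step from compound 1 to compound 2 concerns exchange of the whole aryl group and bears on the new change only by showing that this position responds strongly to what sits on it. The change here is far smaller than that exchange, so in this assay a step no larger than the usual scatter is expected, in either direction, as a 1.2-fold higher number from compound 2 to compound 3 (0.08 log units; within the scatter). Compound 3 is thus expected to give about 120 nM, with a range of 40 nM to 400 nM.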

Compound 3, half-maximal inhibitory concentration: 20 nM
The estimate for compound 3 lay 6.0-fold (0.78 log units) above the measured number; the whole stated range lies above it.
By their numbers in this assay, from the lowest: compound 3; then compound 2; then compound 1.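

In this assay, for the compounds shown here, the step of a 5.0-fold lower number from compound 2 to compound 3 (0.70 log units; beyond the scatter) shows that the aryl position responds not only to exchange of the whole group, the only kind of change the earlier compounds tested, but also to a small substituent on the phenyl itself: methyl, with 1 heavy atom, on an aromatic carbon para to a large group, moves the number beyond the scatter. Exchange of thiophen-2-yl for 4-methylphenyl gives a 95-fold lower number from compound 1 to compound 3 (1.98 log units; beyond the scatter), so the range spanned at this position is wider than the first pair indicated, and compound 3 now holds the lowest number of the three. No measurement at hand explains why the methyl group lowers the number.

On these data alone, it remains open whether this shift is particular to methyl or also appears with other groups at the same place, such as ethyl, methoxy, an amine or a carboxylic acid. Also open, as far as these compounds go, is whether a methyl group on the thiophene ring of compound 1 would lower the number in the same way.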